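Furanyl to Methoxyphenyl Swap on Two Pyrazoline Cores

A few compounds are considered here, and "the series" means these few. Any claim that something is new, unique, unknown or untested is made for them only; others in the source may bear on it.

Measured compounds in a functional assay on HEp-2 cells (Homo sapiens) for cytotoxicity, read by sulforhodamine B assay, with a stated time of 48 h; on this read-out higher numbers stand for weaker inhibition and lower numbers for stronger inhibition:
Compound 1, `CC(=O)N1N=C(c2cccc3ccccc23)CC1c1ccco1`: 17000 nM
Compound 2, `COc1ccc(C2CC(c3cccc4ccccc34)=NN2C(C)=O)cc1`: 3730 nM
Compound 3, `O=CCN1N=C(c2ccc3ccccc3c2)CC1c1ccco1`: 19000 nM

Compound 1 and compound 3 share the same atoms joined differently; the difference between the two cores is not broken down here. Compound 3 and compound 1 give numbers within the usual scatter of each other, while compound 2 is beyond it from both.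

From compound 1 to compound 2 one change is made, (4-methoxyphenyl in place of furan-2-yl on a saturated ring carbon), and it gives a 4.6-fold lower number from compound 1 to compound 2 (0.66 log units; beyond the scatter). Compound 4, `COc1ccc(C2CC(c3ccc4ccccc4c3)=NN2CC=O)cc1`, not yet measured, carries the same kind of change on the core of compound 3, (4-methoxyphenyl in place of furan-2-yl on a saturated ring carbon). Around the place the two differ only in that the ring atom bears a formylmethyl group in compound 4 where it bears an acetyl group in compound 2.

Going by the values given here, because the only measured instance of this change is a 4.6-fold lower number from compound 1 to compound 2 (0.66 log units; beyond the scatter), a step of similar size is expected from compound 3 to compound 4 in this assay, a 4.2-fold lower number from compound 3 to compound 4 (0.63 log units; beyond the scatter), with the range widened for a single precedent. Compound 4 is estimated at 4500 nM, between 2000 nM and 10000 nM.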

Compound 4, half-maximal inhibitory concentration: 3230 nM
Estimate against measurement, compound 4: 1.4-fold (0.14 log units) above; measured number inside the range.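

On the second core, 4-methoxyphenyl in place of furan-2-yl gives a 5.9-fold lower number from compound 3 to compound 4 (0.77 log units; beyond the scatter). In this assay the change therefore carries from one core to the other with no difference in size that can be told apart: the same change on two cores in this assay, a 4.6-fold lower number (0.66 log units; beyond the scatter) from compound 1 to compound 2 and a 5.9-fold lower number (0.77 log units; beyond the scatter) from compound 3 to compound 4, 1.3-fold (0.11 log units) apart, within the scatter of two such steps

This agreement rests on just two cores and a single pair of groups, so it does not show that the step would hold on any further core, and it does not explain why the number falls.

The compounds shown leave open how the number would move with other groups on the saturated ring carbon, such as an unsubstituted phenyl, a 4-chlorophenyl or a phenyl carrying an amine. They also leave open whether the swap would give a similar step if the acetyl or formylmethyl group on the ring nitrogen gave way to a longer chain or a carboxylic acid.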